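Replacing the 1,3-benzothiazol-2-yl group of compound 2

A few compounds are considered here, and "the series" means these few. Any claim that something is new, unique, unknown or untested is made for them only; others in the source may bear on it.

Measured in a functional assay (blood) for inhibition, with Homo sapiens as the target; a lower number here means a stronger inhibitor, a higher number a weaker inhibitor:
- Compound 1 `CC(C)(C)Sc1c(CC(C)(C)C(=O)O)n(Cc2ccc(Cl)cc2)c2ccc(OCc3ccc4cc(F)c(F)cc4n3)cc12`: > 3000 nM, a limit of the assay
- Compound 2 `CC(C)(C)Sc1c(CC(C)(C)C(=O)O)n(Cc2ccc(Cl)cc2)c2ccc(OCc3nc4ccccc4s3)cc12`: 260 nM
- Compound 3 `CC(C)(C)Sc1c(CC(C)(C)C(=O)O)n(Cc2ccc(Cl)cc2)c2ccc(OCc3nc4cc(C(F)(F)F)ccc4s3)cc12`: > 3000 nM, a limit of the assay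

Among the compounds with values here, compound 2 gives the only actual number in the set, 260 nM. Everything else measured stands at the limit of > 3000 nM in this assay, at which 2 of the 3 values shown sit. Compound 4 `CC(COc1ccc2c(c1)c(SC(C)(C)C)c(CC(C)(C)C(=O)O)n2Cc1ccc(Cl)cc1)c1ccccn1` carries 1-(pyridin-2-yl)ethyl in place of 1,3-benzothiazol-2-yl on a saturated chain carbon bound to an oxygen on an aromatic ring. Within the data shown here, two measured steps bear on this change: an at least 11-fold lower number from compound 1 to compound 2 (1.06 log units; beyond the scatter), which exchanges the group at that same carbon, and an at least 11-fold higher number from compound 2 to compound 3 (1.06 log units; beyond the scatter), which puts trifluoromethyl in place of hydrogen on an aromatic carbon. Both are large, and in both compound 2 holds the lower number. Neither makes this exact exchange, so the range stays wide. The expected move in this assay is upward, an estimated 3.1-fold higher number from compound 2 to compound 4 (0.49 log units; beyond the scatter). For compound 4 the expected value is 800 nM, with a range from 200 nM to 3000 nM.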

Compound 4, half-maximal inhibitory concentration: 270 nM
The estimate for compound 4 lay 3.0-fold (0.47 log units) above the measured number; measured number inside the range.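

In this assay, the 1,3-benzothiazol-2-yl group is not required on this saturated chain carbon: 1-(pyridin-2-yl)ethyl, with one six-membered aromatic ring in place of the two fused rings, gives a 1.0-fold higher number from compound 2 to compound 4 (0.02 log units; within the scatter). The group of compound 1 is the one set apart, with an at least 11-fold lower number from compound 1 to compound 4 (1.04 log units; beyond the scatter). Compound 1 stands at a limit of the assay, so that step gives only a bound.

Open, as far as these compounds go, is what pyridin-2-yl alone, without the ethyl chain, would give at this carbon. Also open, from the compounds shown here alone, is whether trifluoromethyl on the pyridin-2-yl ring would be tolerated.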